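Swapping the Ring Substituent on Compound 2

This account rests on a few compounds, and the source may have more. Where it says the series, first, only, none or still open, it means among the compounds named here.

Compound 1 `CC(C)c1coc(-c2cccc(CNc3ccc4[nH]nc(C(=O)O)c4c3)c2O)n1`: 3.6 10^-6 cm/s
Compound 2 `CN(C)c1noc(-c2cccc(CN(C)c3ccc4[nH]nc(C(=O)O)c4c3)c2O)n1`: 3.4 10^-6 cm/s

In an ADME assay on MDCK cells (Canis lupus familiaris) for permeability, in the apical to basolateral direction (on this read-out lower numbers stand for lower permeability and higher numbers for higher permeability), compound 1 gives 3.6 10^-6 cm/s and compound 2 gives 3.4 10^-6 cm/s. Going by the values given here, these two values lie within the usual scatter of each other, so compound 2 stands level with the only other compound measured. Compound 3 `CC(C)c1csc(-c2cccc(CN(C)c3ccc4[nH]nc(C(=O)O)c4c3)c2O)n1` has not yet been measured. It differs from compound 2 in one place: 4-isopropyl-1,3-thiazol-2-yl in place of 3-(dimethylamino)-1,2,4-oxadiazol-5-yl on an aromatic carbon. In words, 4-isopropyl-1,3-thiazol-2-yl takes the place of 3-(dimethylamino)-1,2,4-oxadiazol-5-yl on an aromatic carbon. Among the compounds with values here, no two measured compounds differ in one place alone, so no measured step speaks directly to this change. Compound 1, which also carries an isopropyl group, gives 3.6 10^-6 cm/s, so nothing measured points to a large move. The expected change is small and upward, a 1.3-fold higher number from compound 2 to compound 3 (0.10 log units; within the scatter), and is not expected to go beyond the scatter. For compound 3 the estimated value is 4.3 10^-6 cm/s, with an expected range of 2 10^-6 cm/s to 9 10^-6 cm/s.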

Compound 3, apparent permeability: < 0.05 10^-6 cm/s
Compound 3: only a limit was reported (the forecaster's own chance of this, stated with the estimate: 3%); at least 86-fold (1.93 log units) between middle value and limit.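

Compound 3 gives < 0.05 10^-6 cm/s in this assay, which is a limit of the assay and not a number. At this aromatic carbon, ortho to a hydroxy group, the read-out therefore responds strongly to the group it carries: 4-isopropyl-1,3-thiazol-2-yl in place of 3-(dimethylamino)-1,2,4-oxadiazol-5-yl gives an at least 68-fold lower number from compound 2 to compound 3 (1.83 log units; beyond the scatter). The full size of this step cannot be read, since it is set by a limit: the limit of < 0.05 10^-6 cm/s in this assay, at which 1 of the 3 values shown sits.

Going by these compounds, the step changes the ring and its substituent together, so it remains open whether the 1,3-thiazol-2-yl ring or the isopropyl group accounts for the drop. A dimethylamino group on the 1,3-thiazol-2-yl ring, or an isopropyl group on the 1,2,4-oxadiazol-5-yl ring, would be a single change that could separate the two.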